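Trifluoromethyl for Fluoro on a Methyl-Bearing Core

This account rests on a few compounds, and the source may have more. Where it says the series, first, only, none or still open, it means among the compounds named here.

Compound 1 `Fc1ccc(-c2ccc(-c3ccc(-c4nc5ccccc5[nH]4)cc3)cc2)cc1` and compound 2 `FC(F)(F)c1ccc(-c2ccc(-c3ccc(-c4nc5ccccc5[nH]4)cc3)cc2)cc1` differ by trifluoromethyl in place of fluoro on an aromatic carbon. In a functional assay on MCF7 cells (Homo sapiens) for inhibition, read by sulforhodamine B assay (on this read-out lower numbers stand for stronger inhibition of growth and higher numbers for weaker inhibition of growth), compound 1 gives 36200 nM, and compound 2 gives 41400 nM, so the step is a 1.1-fold higher number from compound 1 to compound 2 (0.06 log units; within the scatter). Compound 3 `Cc1ccc2[nH]c(-c3ccc(-c4ccc(-c5ccc(F)cc5)cc4)cc3)nc2c1` differs from compound 1 by methyl in place of hydrogen on an aromatic carbon; in this assay compound 3 gives 30200 nM, a step of a 1.2-fold lower number from compound 1 to compound 3 (0.08 log units; within the scatter). Compound 4 `Cc1ccc2[nH]c(-c3ccc(-c4ccc(-c5ccc(C(F)(F)F)cc5)cc4)cc3)nc2c1` has not been measured in this assay. It differs from compound 3 by trifluoromethyl in place of fluoro on an aromatic carbon, the same change that separates compound 1 from compound 2, here made on the core of compound 3. Compound 4 is expected to give 33000 nM, within 15000 nM to 70000 nM. The estimate for compound 4 means a step of a 1.1-fold higher number from compound 3 to compound 4 (0.04 log units; within the scatter), resting on the earlier step of a 1.1-fold higher number from compound 1 to compound 2 (0.06 log units; within the scatter) applied to compound 3 and its value of 30200 nM.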

Compound 4, concentration for 50% growth inhibition: 31000 nM
Beside the measured number, compound 4's estimate is 1.1-fold (0.03 log units) above it; the measured number falls inside the stated range.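

In this assay, trifluoromethyl in place of fluoro gives a 1.0-fold higher number from compound 3 to compound 4 (0.01 log units; within the scatter), and the two cores agree on this change: the same change on two cores in this assay, a 1.1-fold higher number (0.06 log units; within the scatter) from compound 1 to compound 2 and a 1.0-fold higher number (0.01 log units; within the scatter) from compound 3 to compound 4, 1.1-fold (0.05 log units) apart, within the scatter of two such steps. Methyl in place of hydrogen gives a 1.3-fold lower number from compound 2 to compound 4 (0.13 log units; within the scatter), and here too the two cores agree: the same change on two cores in this assay, a 1.2-fold lower number (0.08 log units; within the scatter) from compound 1 to compound 3 and a 1.3-fold lower number (0.13 log units; within the scatter) from compound 2 to compound 4, 1.1-fold (0.05 log units) apart, within the scatter of two such steps. For the compounds shown here, each change therefore carries from one core to the other without a visible difference, but since every step lies within the scatter, this shows only that neither change moves the number on these cores, not that a change of real size would carry over in the same way.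

The compounds shown leave open whether an amine or a carboxylic acid in place of the fluoro would move the number at all. They also leave open whether a longer chain in place of the methyl would do so.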